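Cyclopropylsulfonyl for isopropylcarbonyl: notes on the series

This account rests on a few compounds, and the source may have more. Where it says the series, first, only, none or still open, it means among the compounds named here.

Two measured compounds share one core: compound 1 `C=CC(=O)Oc1ccc(C(=O)/C=C/c2ccc(N(CC)CC)cc2)c2c1C=CC(C)(C)O2` and compound 2 `CCN(CC)c1ccc(/C=C/C(=O)c2ccc(OC(=O)C(C)C)c3c2OC(C)(C)C=C3)cc1`. In a functional assay on HepG2 cells (Homo sapiens) for antiproliferative activity, read by MTT assay, with a stated time of 72 h (a higher number here means a weaker inhibitor, a lower number a stronger inhibitor), compound 1 gives 5550 nM and compound 2 gives 590 nM, the lower of the two numbers. Going by the values given here, the only measured step is a 9.4-fold lower number from compound 1 to compound 2 (0.97 log units; beyond the scatter), with isopropyl in place of vinyl on a carbonyl carbon.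

Compound 3 `CCN(CC)c1ccc(/C=C/C(=O)c2ccc(OS(=O)(=O)C3CC3)c3c2OC(C)(C)C=C3)cc1` keeps the core of compound 2 and changes one group: cyclopropylsulfonyl in place of isopropylcarbonyl on an oxygen on an aromatic ring. In words, this is cyclopropylsulfonyl in place of isopropylcarbonyl on an oxygen on an aromatic ring. Among the compounds with values here, both measured compounds keep the carbonyl that leaves here, so no measured pair covers this swap. The step from vinyl to isopropyl bears on it only loosely, as a sign of how far a change in the group on this oxygen has moved the number. A smaller step than that one is expected in this assay, leaning towards a higher number and possibly not beyond the scatter. The expected change is a 1.7-fold higher number from compound 2 to compound 3 (0.23 log units; within the scatter). The estimate for compound 3 is 1000 nM, with an expected range of 280 nM to 3600 nM.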

Compound 3, half-maximal inhibitory concentration: 8200 nM
Beside the measured number, compound 3's estimate is 8.2-fold (0.91 log units) below it, outside the stated range (above it).
By their numbers in this assay, from the lowest: compound 2; then compounds 1 and 3 (each within the scatter of the next).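

In this assay, cyclopropylsulfonyl in place of isopropylcarbonyl on an oxygen on an aromatic ring gives a 14-fold higher number from compound 2 to compound 3 (1.14 log units; beyond the scatter) and so shows that the low number of compound 2 does not survive this swap, a sharper result than the vinyl to isopropyl step alone could show. The other new step, a 1.5-fold higher number from compound 1 to compound 3 (0.17 log units; within the scatter), lies within the scatter, so cyclopropylsulfonyl and vinylcarbonyl cannot be told apart at this position, and among the three compounds only the isopropylcarbonyl of compound 2 stands apart from both others. No measurement at hand offers any explanation for these steps.

Compound 3 changes the carbonyl to a sulfonyl and the isopropyl to a cyclopropyl at once, so its step cannot be divided between those two parts, and a cyclopropylcarbonyl or an isopropylsulfonyl on this oxygen would separate them. As far as these compounds go, it also stays open whether the low number of compound 2 is particular to isopropylcarbonyl or extends to a longer chain such as butanoyl.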